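Replacing the free amino group with an aromatic imine

The source may hold more compounds than are shown below. What is called first, only, known or untested is meant among the compounds shown, and "the series" means these compounds.

Measured so far:
Compound 1 `COC(=O)C(=O)NC1=C(C#N)C2C(N3CCCC3)CCCCN2C(=O)N1c1ccccc1` gives 88.3% in a functional assay on the whole organism (strain albino) for inhibition, with Rattus norvegicus as the target, read by paw edema, with stated times of 1 h and 3 h, at a dose of 20 mmol/kg by the intraperitoneal route; on this read-out higher numbers stand for a stronger effect at the one dose given and lower numbers for a weaker effect.
Compound 2 `CCOC(=O)C(=O)NC1=C(C#N)C2C(N3CCCC3)CCCCN2C(=O)N1c1ccccc1` gives 91.5% in this assay.
Compound 3 `N#CC1=C(N)N(c2ccccc2)C(=O)N2CCCCC(N3CCCC3)C12` gives 90.1% in this assay.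

Compound 3 stands second of the three numbers, but its neighbours are close: a number 1.4 percentage points lower from compound 2 to compound 3 (within the scatter) and a number 1.8 percentage points higher from compound 1 to compound 3 (within the scatter), both within the scatter. Compound 4 `N#CC1=C(/N=C/c2ccc([N+](=O)[O-])cc2)N(c2ccccc2)C(=O)N2CCCCC(N3CCCC3)C12` has not yet been measured. It differs from compound 3 as follows: a group of 11 heavy atoms (7 carbon, 2 nitrogen, 2 oxygen; one six-membered aromatic ring of carbon only) in place of one nitrogen atom, on a double-bonded ring carbon

The measured steps all concern the amine nitrogen of the shared core: adding a (methoxycarbonyl)carbonyl or (ethoxycarbonyl)carbonyl group, or lengthening one of these by a methyl, changed nothing beyond the scatter. For the measured compounds named here, the change to compound 4 touches the same position but brings in a larger, aromatic group of a new kind, for which no measured step exists. Going by the values given here, since every change at this position so far has left the result level, compound 4 is expected to stay near compound 3, with the step of a number 5.1 percentage points lower from compound 3 to compound 4 (within the scatter) taken as a cautious guess. The estimate for compound 4 is 85%, within a range from 65% to 96%.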

Compound 4, a percentage reported as inhibition, in the whole organism at one dose (the size of the read-out at that dose, not a potency): 91.7%
Compound 4: the middle estimate sits 6.7 percentage points below what was measured; low and high end bracket the measured number.
By their numbers in this assay, from the lowest: compounds 1, 3, 2 and 4 (each within the scatter of the next).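

In this assay the group of 11 heavy atoms, with its six-membered aromatic ring, takes the place of the amino group and gives a number 1.6 percentage points higher from compound 3 to compound 4 (within the scatter), so this position accepts a far larger aromatic group without a shift beyond the scatter. The comparisons with the two compounds carrying an ester-bearing group at this position read the same way, with a number 0.2 percentage points higher from compound 2 to compound 4 (within the scatter) and a number 3.4 percentage points higher from compound 1 to compound 4 (within the scatter), and the one hydrogen-bond donor of the amino group can go without moving the number beyond the scatter. No measurement here gives a reason for this tolerance.

Going by these compounds, whether a plain phenyl ring without the nitro group, a pyridine ring or a simple alkyl chain on the same nitrogen would also stay within the scatter remains open. A single dose also leaves open any difference in potency among these compounds.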